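Swapping the aryl group on the amine-bound benzylic carbon

A few compounds are considered here, and "the series" means these few. Any claim that something is new, unique, unknown or untested is made for them only; others in the source may bear on it.

Measured so far:
compound 1 `O=S(=O)(NCCCNCc1ccc(Cl)c(Cl)c1)c1cc(C(F)(F)F)cc(C(F)(F)F)c1`: 2900 nM
compound 2 `O=S(=O)(NCCCNCc1ccc(C(F)(F)F)cc1)c1cc(C(F)(F)F)cc(C(F)(F)F)c1`: 2700 nM

Both compounds share one core and differ only in the aryl group on a saturated chain carbon bound to an amine nitrogen. In a functional assay on BE(2)-C cells (Homo sapiens) for inhibition, read by MTT assay, with a stated time of 72 h (on this read-out higher numbers stand for weaker inhibition of growth and lower numbers for stronger inhibition of growth), compound 1 gives 2900 nM and compound 2 gives 2700 nM; the step of a 1.1-fold lower number from compound 1 to compound 2 (0.03 log units; within the scatter) shows that this exchange made no difference that the assay can resolve. Compound 2 holds the lowest of the two numbers, but its gap to compound 1 is within the scatter.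

Compound 3 `O=S(=O)(NCCCNCc1cccc2ccccc12)c1cc(C(F)(F)F)cc(C(F)(F)F)c1` changes the same position again: naphthalen-1-yl in place of 4-(trifluoromethyl)phenyl on a saturated chain carbon bound to an amine nitrogen. Going by the values given here, the only measured step that touches this position is the one from compound 1 to compound 2, and it was flat. Compound 3 is therefore expected to land close to compound 2, with a step of a 1.1-fold lower number from compound 2 to compound 3 (0.03 log units; within the scatter) in this assay. The estimate for compound 3 is 2500 nM, with a range from 1000 nM to 6500 nM.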

Compound 3, concentration for 50% growth inhibition: 2700 nM
The estimate for compound 3 lay 1.1-fold (0.03 log units) below the measured number; low and high end bracket the measured number.
By their numbers in this assay, from the lowest: compounds 2, 3 and 1 (each within the scatter of the next).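

In this assay there is no change at the digits printed from compound 2 to compound 3 (within the scatter), and there is a 1.1-fold lower number from compound 1 to compound 3 (0.03 log units; within the scatter). Until now this position had been tried only with single-ring groups carrying halogen atoms, whereas naphthalen-1-yl has 2 six-membered aromatic rings of carbon only and no halogen, yet all three aryl groups give numbers within the scatter of one another. Nothing available explains why these exchanges leave the number in this range.

On these data alone, all three compounds carry an all-carbon aromatic group here, so it remains open whether a pyridine ring or a cyclohexyl group on a saturated chain carbon bound to an amine nitrogen would read the same. Also open, as far as these compounds go, is whether a longer chain in the shared core would give a number beyond the scatter of these three.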